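This account rests on a few compounds, and the source may have more. Where it says the series, first, only, none or still open, it means among the compounds named here.

Measured in a functional assay on A498 cells (Homo sapiens) for cytotoxicity, read by sulforhodamine B assay, with a stated time of 48 h; on this read-out higher numbers stand for weaker inhibition of growth and lower numbers for stronger inhibition of growth:
Compound 1 `Nc1nc(Cl)c2ncn(Cc3ccccc3CCl)c2n1` gives 20400 nM.
Compound 2 `ClCc1cccc(Cn2cnc3nc(Cl)nc(Cl)c32)c1` gives 1510 nM.
Compound 3 `ClCc1ccccc1Cn1cnc2nc(Cl)nc(Cl)c21` gives 2510 nM.

Compound 1 has the highest number of the three, so among these it inhibits growth least strongly. Its nearest neighbour, compound 3, has a clearly lower number, and compound 2 a lower number still; both gaps lie beyond the usual scatter. No two of these compounds differ in a single place, so no measured step between them is known.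

Compound 4 `ClCc1ccccc1Cn1cnc2c(Cl)ncnc21` has not yet been measured. It differs from compound 1 in one place: hydrogen in place of amino on an aromatic carbon. Compounds 2 and 3 share no such single change with compound 4, so their much lower numbers give only a loose hint that this position matters. The step in this assay is expected to be modest, most likely toward a lower number, though it may well stay within the scatter. Compound 4 is estimated at 8000 nM, with a range from 2500 nM to 25000 nM. This estimate means an expected 2.6-fold lower number from compound 1 to compound 4 (0.41 log units; beyond the scatter).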

Compound 4, concentration for 50% growth inhibition: 17400 nM
For compound 4 the middle estimate is 2.2-fold (0.34 log units) below the measured one, within the range that was stated.
By their numbers in this assay, from the lowest: compounds 2 and 3 (each within the scatter of the next); then compounds 4 and 1 (each within the scatter of the next).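

In this assay, putting hydrogen in place of amino on the aromatic carbon between two ring nitrogen atoms gives a 1.2-fold lower number from compound 1 to compound 4 (0.07 log units; within the scatter), a step within the usual scatter. Within the data shown here, this is the first single change that can be read in this set, and it shows that, on the core of compound 1, removing the amino group leaves no change in growth inhibition that this assay can distinguish from repeat-to-repeat variation. No measurement shown here offers an explanation for this result.

Going by these compounds, whether a different group on this same carbon, such as a methylamino group, a methoxy group or a longer chain, would shift the number remains open. So does whether hydrogen in place of amino would behave the same way on any other compound, since this single pair is the only example.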